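Ethyl for methoxy in a series sitting at the limit

A few compounds are considered here, and "the series" means these few. Any claim that something is new, unique, unknown or untested is made for them only; others in the source may bear on it.

In a functional assay on HT-29 cells (Homo sapiens) for inhibition, read by sulforhodamine B assay, with a stated time of 48 h (on this read-out higher numbers stand for weaker inhibition of growth and lower numbers for stronger inhibition of growth), compound 1 (`S=C(N/N=C/c1cccs1)Nc1ccccc1`) gives > 100000 nM as a limit of the assay and not a number. Compound 2 (`COc1ccc(NC(=S)N/N=C/c2cccs2)cc1`) gives > 100000 nM as a limit too, so its standing is known only as a limit. The record so far amounts to the limit of > 100000 nM in this assay, at which 2 of the 2 values shown sit, and holds no numerical value.

Compound 3 (`CCc1ccc(NC(=S)N/N=C/c2cccs2)cc1`) carries ethyl in place of methoxy on an aromatic carbon, para to a large group (ethyl in place of methoxy on an aromatic carbon). For the measured compounds named here, the only measured step that bears on this change is a step that the two limits leave unreadable from compound 1 to compound 2 and it offers no size to carry over. No direction can therefore be expected in this assay. The expected step of a number no higher from compound 2 to compound 3 (the limit leaves the size open) is estimated to stay within the usual scatter. For compound 3 the estimated value is 100000 nM with an expected range of 30000 nM to 300000 nM and another limit is the likeliest report.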

Compound 3, concentration for 50% growth inhibition: > 100000 nM
Compound 3: a limit, no number; the forecaster's own chance of this, stated with the estimate: 75%; the middle value sits exactly at the limit.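

The steps among compound 1, compound 2 and compound 3 cannot be read in this assay, since each compound gives a limit and not a number: the limit of > 100000 nM in this assay, at which 3 of the 3 values shown sit.

On these data alone, whether hydrogen, methoxy and ethyl on the aromatic carbon differ in growth inhibition, and in which direction or by how much, stays open.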